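This account rests on a few compounds, and the source may have more. Where it says the series, first, only, none or still open, it means among the compounds named here.

Compound 1 `Cc1nc(-c2cccc3ccccc23)sc1COc1ccc2c(c1)OCC2CC(=O)O` and compound 2 `Cc1ccccc1-c1nc(C)c(COc2ccc3c(c2)OCC3CC(=O)O)s1` share one core and differ only in the aromatic group attached to it. In a functional assay on CHO cells for agonist activity at Free fatty acid receptor 1 (Homo sapiens), read by FLIPR and calcium flux, tested at 100 nM (on this read-out higher numbers stand for a stronger effect at the one concentration tested and lower numbers for a weaker effect), compound 1 gives 8.53% and compound 2 gives 10.7%. The move between them is a number 2.2 percentage points higher from compound 1 to compound 2 (within the scatter). Of the two numbers compound 2 stands at the top, though its distance to compound 1 is within the scatter. Compound 3 `Cc1nc(-c2ccccc2Cl)sc1COc1ccc2c(c1)OCC2CC(=O)O` differs from compound 2 by chloro in place of methyl on an aromatic carbon. Going by the values given here, no measured step involves a swap of this kind, and the only measured step concerned a different group and stayed within the scatter. For compound 3 the expected step is a number 0.7 percentage points lower from compound 2 to compound 3 (within the scatter), nothing beyond the scatter. The estimate for compound 3 is therefore 10%, with a range from 0% to 25%.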

Compound 3, a percentage reported as activity, at one concentration (the size of the read-out at that concentration, not a potency): 12.4%
Compound 3: the middle estimate sits 2.4 percentage points below what was measured; measured number inside the range.
By their numbers in this assay, from the lowest: compounds 1, 2 and 3 (each within the scatter of the next).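

In this assay chloro in place of methyl, ortho to a large group, gives a number 1.7 percentage points higher from compound 2 to compound 3 (within the scatter) and 2-chlorophenyl in place of naphthalen-1-yl gives a number 3.9 percentage points higher from compound 1 to compound 3 (within the scatter) and so all three groups now read alike at this position. Going by these compounds alone, this is the first swap of one heavy atom here, and it leaves the read-out within the scatter, as the larger swap does. Nothing measured bears on why these numbers lie so close.

Still open, on these data alone, is whether another group at this place, such as methoxy or an amine, would move the read-out beyond the scatter. A single concentration also leaves open whether these three compounds differ in potency.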